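Removing the Hydroxy from the Aroyl Group of Compound 3

A few compounds are considered here, and "the series" means these few. Any claim that something is new, unique, unknown or untested is made for them only; others in the source may bear on it.

Compound 3 `CC1=C/C(=N\NC(=O)c2ccccc2O)c2c(O)cccc2C1=O` gives 3800 nM in a functional assay on MDA-MB-231 cells (Homo sapiens) for antiproliferative activity, read by MTT assay, with a stated time of 24 h; on this read-out higher numbers stand for weaker inhibition and lower numbers for stronger inhibition. Compound 1 `CC1=C/C(=N\NC(=O)c2ccncc2)c2c(O)cccc2C1=O` gives 3300 nM and compound 2 `CC1=C/C(=N\NC(=O)c2cccnc2)c2c(O)cccc2C1=O` gives 1900 nM. The step of a 1.2-fold higher number from compound 1 to compound 3 (0.06 log units; within the scatter) and the step of a 2.0-fold higher number from compound 2 to compound 3 (0.30 log units; within the scatter) both stay within the scatter, as does a 1.7-fold lower number from compound 1 to compound 2 (0.24 log units; within the scatter), so compound 3 sits among the other two rather than apart from them. Compound 4 `CC1=C/C(=N\NC(=O)c2ccccc2)c2c(O)cccc2C1=O` differs from compound 3 by hydrogen in place of hydroxy on an aromatic carbon. Among the compounds with values here, none of the measured steps removes a hydroxy from an aryl group; each exchanges one whole aryl group for another, and all three stayed within the scatter. Within the data shown here, no measured step therefore bears directly on this change, and in this assay no step beyond the scatter is expected. The step expected from compound 3 to compound 4 is no change at the digits printed from compound 3 to compound 4 (within the scatter). Compound 4 is expected to give 3800 nM, within a range from 1500 nM to 9500 nM.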

Compound 4, half-maximal inhibitory concentration: 2100 nM
Estimate against measurement, compound 4: 1.8-fold (0.26 log units) above; measured number inside the range.
By their numbers in this assay, from the lowest: compounds 2, 4, 1 and 3 (each within the scatter of the next).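

In this assay, within the data shown here, taking the hydroxy off the 2-hydroxyphenyl group gives a 1.8-fold lower number from compound 3 to compound 4 (0.26 log units; within the scatter), so this change, tested directly for the first time, stays within the scatter. The plain phenyl group also sits with both pyridinyl groups, at a 1.1-fold higher number from compound 2 to compound 4 (0.04 log units; within the scatter) and a 1.6-fold lower number from compound 1 to compound 4 (0.20 log units; within the scatter), so all four aroyl groups read alike here.

From the compounds shown here alone, whether an amine or a carboxylic acid in that place would read the same stays open, as does any change to the shared core. Nothing measured here speaks to a cause for these steps.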